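This account rests on a few compounds, and the source may have more. Where it says the series, first, only, none or still open, it means among the compounds named here.

Working notes on the series. Compound 1 `Cc1ccc(C(=O)Nc2ncc(Cc3ccc(F)cc3)s2)cc1` is recorded in an ADME assay on HepG2 2.2.15 cells (Homo sapiens) for cytotoxicity (on this read-out higher numbers stand for lower toxicity in this test and lower numbers for higher toxicity in this test), as "not toxic" (no number reported). Compound 2 `CC(C)(C)OC(=O)Nc1ncc(C(Oc2ccc(Br)cc2)c2ccc(Cl)cc2)s1` reaches only the limit of this assay, > 50000 nM. Compound 3 `CCCCCC(=O)Nc1ncc(C(Oc2ccc3cc(Br)ccc3c2)c2ccc(Cl)cc2)s1` likewise gives no number in this assay but a limit, > 50000 nM. Among the measured compounds shown here, compound 3 therefore stands at the ceiling of what has been measured, at the limit of > 50000 nM in this assay, at which 2 of the 3 values shown sit; none of the three measured compounds reads as a number, so no step between measured compounds can be computed and nothing in the measured set marks a direction.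

Compound 4 `N#Cc1cccc(C(=O)Nc2ncc(C(Oc3ccc4cc(Br)ccc4c3)c3ccc(Cl)cc3)s2)c1` differs from compound 3 in one place: 3-cyanophenyl in place of pentyl on a carbonyl carbon. Because (the limit of > 50000 nM in this assay, at which 2 of the 3 values shown sit), the expected step in this assay is a number no higher from compound 3 to compound 4 (the limit leaves the size open), none beyond the scatter, with the read-out most likely again reported only as a limit rather than a number. Compound 4 is accordingly estimated at 50000 nM in this assay, within 20000 nM to 100000 nM, pending the measurement.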

Compound 4, half-maximal cytotoxic concentration: > 50000 nM
Compound 4 was reported as a limit (the forecaster's own chance of this, stated with the estimate: 80%); the middle value sits exactly at the limit.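

No step can be read between compound 3 and compound 4 in this assay, as both results are limits rather than numbers: the limit of > 50000 nM in this assay, at which 3 of the 4 values shown sit.

The compounds shown leave open whether 3-cyanophenyl in place of pentyl on a carbonyl carbon changes this read-out at all.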